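A few compounds are considered here, and "the series" means these few. Any claim that something is new, unique, unknown or untested is made for them only; others in the source may bear on it.

Measured so far:
compound 1 `CC(=O)c1ccc(OCCCCC#N)cc1O`: 0%
compound 2 `CCCc1cc(C(C)=O)ccc1OCCCCC#N`: 44%
compound 3 `CCCc1cc(C(C)=O)c(O)c(CCC)c1OCCCCC#N`: 0%

All three were run in an assay on isolated protein for inhibition of leukotriene B4 receptor 1 (Homo sapiens), tested at 10 uM; a higher number here means more inhibition at the concentration tested (going by the name of the read-out), a lower number less inhibition. Compound 3 stands level with compound 1 at the digits shown, the two together the lowest of the three numbers; the gap between them lies within the scatter, while compound 2 sits higher by a margin beyond it. Compound 4 `CCCc1c(OCCCCC#N)ccc(C(C)=O)c1O` differs from compound 3 by hydrogen in place of propyl on an aromatic carbon, the other propyl and the hydroxy group being kept. For the measured compounds named here, no step between measured compounds covers this change. Both hydroxy-bearing compounds measured, compound 1 at 0% and compound 3 at 0%, sit at the bottom, so only a small upward step, if any beyond the scatter, is expected. The expected step is a number 12 percentage points higher from compound 3 to compound 4 (beyond the scatter). Compound 4 is estimated at 12%, range 0% to 35%.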

Compound 4, a percentage reported as inhibition, at one concentration (the size of the read-out at that concentration, not a potency): 0%
Estimate against measurement, compound 4: 12 percentage points above, within the range that was stated.
By their numbers in this assay, from the lowest: compounds 1, 3 and 4 (each within the scatter of the next); then compound 2.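

In this assay hydrogen in place of the propyl ortho to the 4-cyanobutoxy group gives no change at the digits printed from compound 3 to compound 4 (within the scatter) and so does not lift the reading with the hydroxy group kept. Propyl in place of hydrogen on an aromatic carbon gives no change at the digits printed from compound 1 to compound 4 (within the scatter) in the same setting. Hydroxy in place of hydrogen gives a number 44 percentage points lower from compound 2 to compound 4 (beyond the scatter) and is the only one of these steps beyond the scatter, with no compound shown going against it.

Nothing at hand explains this drop. Going by these compounds, whether an amine or a carboxylic acid in place of the hydroxy group also lowers the number remains open.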